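The compounds below may be only part of what the source reports. "The series", "measured", "known", "first", "only" and "open" are said of these compounds alone.

Compound 1 `CC(C(=O)NCc1ccc(C(F)(F)F)nc1Cl)c1ccc(NS(C)(=O)=O)c(F)c1` is the strongest of the three measured compounds in an assay on CHO cells for antagonist activity at transient receptor potential cation channel subfamily V member 1 (Homo sapiens), read by FLIPR and calcium flux (a higher number here means a weaker inhibitor, a lower number a stronger inhibitor), where compound 1 gives 0.2 nM. Compound 3 `CC(C(=O)NCc1ccc(C(F)(F)F)nc1CCC(C)(C)C)c1ccc(NS(C)(=O)=O)c(F)c1` is close behind; in this assay compound 3 gives 0.6 nM. Among the compounds with values here, compound 2 `CC(C(=O)NCc1ccc(C(F)(F)F)nc1Br)c1ccc(NS(C)(=O)=O)c(F)c1` stands apart as the highest number of the three: in this assay compound 2 gives 169 nM, and the only difference from compound 1 is an 850-fold higher number from compound 1 to compound 2 (2.93 log units; beyond the scatter).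

Compound 4 `CC(C(=O)NCc1ccc(C(F)(F)F)nc1/C=C/C1CCCCC1)c1ccc(NS(C)(=O)=O)c(F)c1` differs from compound 2 in a single place: 2-cyclohexylethenyl in place of bromo on an aromatic carbon. The measured step that bears most directly on this is a 280-fold lower number from compound 2 to compound 3 (2.45 log units; beyond the scatter), where a large carbon chain replaced the same bromo at the same place and the number fell sharply. Compound 1 and compound 3 differ by a 3.0-fold higher number from compound 1 to compound 3 (0.48 log units; beyond the scatter), so two very different groups at this position both give low numbers while bromo alone gives a high one. A 2-cyclohexylethenyl group is another large carbon group, so a large drop is expected, a 170-fold lower number from compound 2 to compound 4 (2.23 log units; beyond the scatter), landing near the values of compound 1 and compound 3. For compound 4 the estimate in this assay is 1 nM, with a range from 0.2 nM to 10 nM.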

Compound 4, inhibition constant: 0.7 nM
Beside the measured number, compound 4's estimate is 1.4-fold (0.15 log units) above it; the range from low to high includes it.
By their numbers in this assay, from the lowest: compound 1; then compounds 3 and 4 (each within the scatter of the next); then compound 2.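

Replacing bromo with 2-cyclohexylethenyl gives a 240-fold lower number from compound 2 to compound 4 (2.38 log units; beyond the scatter) in this assay and so adds a second large carbon group that escapes the high number of compound 2, this time with a six-membered ring and a double bond outside aromatic rings. The group on compound 4 and the open 3,3-dimethylbutyl chain cannot be told apart here, with a 1.2-fold higher number from compound 3 to compound 4 (0.07 log units; within the scatter) as their step, so this position accepts both shapes among the compounds shown. Chloro still keeps a modest edge, seen in a 3.5-fold higher number from compound 1 to compound 4 (0.54 log units; beyond the scatter) for this pair, and no measurement here explains why bromo alone stands out.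

Every group shown at this position is a halogen or a hydrocarbon group. From the compounds shown here alone, how an amine, a carboxylic acid or an ether would behave there remains open, as does whether a small methyl would give a low number or a high one.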